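Swapping Chloro for Isopropoxy on the Fused Ring

The source may report more compounds than this note shows. Statements on the series, on what has been measured and on what is new or still open speak of the compounds shown alone.

Going by the values given here, compound 1 `CC#C[C@@H](CC(=O)O)c1ccc(OC[C@H]2COc3ccc(Cl)cc3O2)cc1` holds the lowest number of the two compounds measured so far in a functional assay on HEK293 cells for agonist activity at Free fatty acid receptor 1 (Homo sapiens), read by fluorescence and calcium flux, with a stated time of 10 min (on this read-out lower numbers stand for an effect already at smaller amounts and higher numbers for an effect only at larger amounts of compound), where compound 1 gives 50 nM. Among the compounds with values here, its only measured neighbour is compound 2 `CC#C[C@H](CC(=O)O)c1ccc(OC[C@H]2COc3ccc(Cl)cc3O2)cc1`, which in this assay gives 3400 nM. The step of a 68-fold higher number from compound 1 to compound 2 (1.83 log units; beyond the scatter) rests on the fact that compounds 1 and 2 differ only in the configuration as drawn: the two compounds share every atom and bond and differ only at one stereocentre on the saturated chain.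

Compound 3 `CC#C[C@@H](CC(=O)O)c1ccc(OC[C@H]2COc3ccc(OC(C)C)cc3O2)cc1` keeps the configuration of compound 1 and changes the fused ring instead: isopropoxy in place of chloro on an aromatic carbon. Within the data shown here, no measured step bears on this change, because the single step available concerns configuration alone and says nothing about replacing one group with another on the aromatic ring. The expectation therefore rests on compound 1 by itself, and the step of a 1.6-fold higher number from compound 1 to compound 3 (0.20 log units; within the scatter) is expected to be small, with no direction beyond the scatter that can be foreseen. Compound 3 is estimated to give 80 nM in this assay, within a range from 20 nM to 400 nM.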

Compound 3, half-maximal effective concentration: 280 nM
Estimate against measurement, compound 3: 3.5-fold (0.54 log units) below; the measured number falls inside the stated range.
By their numbers in this assay, from the lowest: compound 1; then compound 3; then compound 2.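

Going by these compounds alone, replacing chloro with isopropoxy gives a 5.6-fold higher number from compound 1 to compound 3 (0.75 log units; beyond the scatter) in this assay, and this is the first measured sign that the group on this aromatic carbon of the fused ring affects the number, as the earlier pair varied only the configuration on the saturated chain. The position is not indifferent to its group, yet it does not rule out a larger one: with 4 heavy atoms (3 carbon, 1 oxygen) in place of 1 chlorine, compound 3 still gives 280 nM with the configuration of compound 1 kept. Nothing measured here speaks to the reason for this step, so the result records the size of the change and not its cause.

The compounds shown leave open whether the rise in the number goes with the greater size of isopropoxy or with its oxygen, a question that a methoxy, fluoro or nitrile group at the same carbon could begin to answer. They also leave open whether the configuration on the saturated chain matters as much when isopropoxy stands on the ring as it does when chloro stands there.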